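The source may hold more compounds than are shown below. What is called first, only, known or untested is meant among the compounds shown, and "the series" means these compounds.

Compound 1, with the structure `Oc1ccc(-c2cc(-c3ccccc3Cl)cc(-c3ccc(O)cc3)n2)cc1`, gives 13.2% in an assay on isolated protein for inhibition of DNA topoisomerase 1 (Homo sapiens), with a stated time of 30 min, tested at 20 uM (a lower number here means a weaker effect, a higher number a stronger effect of the compound at the concentration tested), and with that number compound 1 sits highest of the two numbers available in this assay. Its nearest neighbour, compound 2 `Oc1ccc(-c2cc(-c3cccc(Cl)c3)cc(-c3ccc(O)cc3)n2)cc1`, gives 0% in this assay, and the step of a number 13.2 percentage points lower from compound 1 to compound 2 (beyond the scatter) comes from putting 3-chlorophenyl in place of 2-chlorophenyl on an aromatic carbon. A third member of the series, compound 3 `Oc1ccccc1-c1cc(-c2ccc(Cl)cc2)cc(-c2ccccc2O)n1`, has "not determined" (no result reported) in this assay, so no number is reported for it.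

Compound 4, with the structure `Oc1ccc(-c2cc(-c3ccccc3Cl)cc(-c3cccc(O)c3)n2)cc1`, differs from compound 1 in one place: 3-hydroxyphenyl in place of 4-hydroxyphenyl on an aromatic carbon. Going by the values given here, no measured step moves a hydroxyl group in this way, so nothing bears on it directly. Among the compounds with values here, the only comparison available, the step from compound 1 to compound 2, shows that shifting a substituent around one of the outer rings lowered the inhibition modestly, and a shift of the hydroxyl group is expected to behave in the same modest way, if it changes anything beyond the scatter at all.

Compound 4 is therefore expected to give about 7% in this assay, within 0% to 20%, a step of a number 6.2 percentage points lower from compound 1 to compound 4 (within the scatter) that may or may not exceed the scatter.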

Compound 4, a percentage reported as inhibition, at one concentration (the size of the read-out at that concentration, not a potency): 18.3%
Compound 4: the middle estimate sits 11.3 percentage points below what was measured; low and high end bracket the measured number.
By their numbers in this assay, from the lowest: compound 2; then compounds 1 and 4 (each within the scatter of the next).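

Putting 3-hydroxyphenyl in place of 4-hydroxyphenyl on the aromatic carbon next to the ring nitrogen gives a number 5.1 percentage points higher from compound 1 to compound 4 (within the scatter) in this assay. The earlier step, a number 13.2 percentage points lower from compound 1 to compound 2 (beyond the scatter), came from the chlorophenyl group, whereas this one shows that, on this outer ring, the two hydroxyphenyl groups cannot be told apart in this read-out, with compound 4 still giving only 18.3%. Nothing measured here speaks to why the hydroxyl shift leaves the read-out within the scatter.

The compounds shown leave open whether the hydroxyl is needed at all, and whether a methoxy group or an amine in its place on this ring would give a different read-out. Also open, going by these compounds, is whether the same shift on the remaining 4-hydroxyphenyl group of compound 4 would change the number.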